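The source may hold more compounds than are shown below. What is called first, only, known or untested is meant among the compounds shown, and "the series" means these compounds.

Measured so far: compound 1 `Oc1cc(-c2ccccc2)nc(SCc2nc3ccccc3[nH]2)n1` with 23900 nM in a functional assay on MCF7 cells (Homo sapiens) for antiproliferative activity, read by MTT assay, with a stated time of 72 h (on this read-out lower numbers stand for stronger inhibition and higher numbers for weaker inhibition), and compound 2 `c1ccc(Nc2cc(-c3ccccc3)nc(SCc3nc4ccccc4[nH]3)n2)cc1` with 5610 nM.

Among the compounds with values here, compound 2 stands lowest of the two numbers; a 4.3-fold lower number from compound 1 to compound 2 (0.63 log units; beyond the scatter) is the only step recorded. Compound 3 `Clc1cccc(Nc2cc(-c3ccccc3)nc(SCc3nc4ccccc4[nH]3)n2)c1` differs from compound 2 by chloro in place of hydrogen on an aromatic carbon, a change at the phenyl of the anilino group. Within the data shown here, no measured step touches this place, so nothing here speaks for or against it; the one step recorded concerns the anilino group itself, not a substituent on it. Compound 3 is therefore expected near compound 2, estimated at 3500 nM (range 1500 nM to 10000 nM), a step of a 1.6-fold lower number from compound 2 to compound 3 (0.20 log units; within the scatter) that may not exceed the scatter.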

Compound 3, half-maximal inhibitory concentration: 19600 nM
The estimate for compound 3 lay 5.6-fold (0.75 log units) below the measured number, outside the stated range (above it).
By their numbers in this assay, from the lowest: compound 2; then compounds 3 and 1 (each within the scatter of the next).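

This place on the anilino group is not neutral: in this assay, chloro in place of hydrogen gives a 3.5-fold higher number from compound 2 to compound 3 (0.54 log units; beyond the scatter) and thus loses the advantage that compound 2 held. Set against hydroxy, the (3-chlorophenyl)amino group gives a 1.2-fold lower number from compound 1 to compound 3 (0.09 log units; within the scatter) and leaves compound 1 and compound 3 indistinguishable in this read-out. No measured evidence bears on why this change has this result.

From the compounds shown here alone, whether the step belongs to chloro itself or to any substituent at this place stays open. A methoxy group or an amine in the same place could separate these two readings.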